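Swapping the ring on the amide nitrogen of compound 2

A few compounds are considered here, and "the series" means these few. Any claim that something is new, unique, unknown or untested is made for them only; others in the source may bear on it.

Measured so far:
Compound 1 `CN1CCC(NC(=O)c2ccncc2Nc2cc(-c3ccc4ccn(C)c4c3)c3nccnc3c2)CC1` gives 38 nM in an assay for inhibition of 6-phosphofructo-2-kinase/fructose-2,6-bisphosphatase 3 (Homo sapiens), read by ADP-Glo, with a stated time of 2 h; a higher number here means a weaker inhibitor, a lower number a stronger inhibitor.
Compound 2 `Cn1ccc2ccc(-c3cc(Nc4cnccc4C(=O)NC4CCNC(=O)C4)cc4nccnc34)cc21` gives 69 nM in this assay.

Among the measured compounds shown here, compound 2 is one of only two measured compounds, and its number sits within the scatter of the number for compound 1: the step of a 1.8-fold higher number from compound 1 to compound 2 (0.26 log units; within the scatter) is too small to count as a real difference. Compound 3 `Cn1ccc2ccc(-c3cc(Nc4cnccc4C(=O)NCC4COCCN4)cc4nccnc34)cc21` has not been measured. It differs from compound 2 in one place: (morpholin-3-yl)methyl in place of 2-oxopiperidin-4-yl on an amide-type nitrogen. For the measured compounds named here, the only measured step that bears on this site is the one from compound 1 to compound 2, where a different group on the same amide nitrogen changed the number by a 1.8-fold higher number from compound 1 to compound 2 (0.26 log units; within the scatter), which is within the scatter. With so little to go on, the expectation for compound 3 is a step of about a 1.4-fold higher number from compound 2 to compound 3 (0.16 log units; within the scatter) in this assay, at most a modest weakening. Compound 3 is therefore estimated at 100 nM, with a range from 35 nM to 300 nM.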

Compound 3, half-maximal inhibitory concentration: 33 nM
Compound 3: the middle estimate sits 3.0-fold (0.48 log units) above what was measured, outside the stated range (below it).
By their numbers in this assay, from the lowest: compounds 3, 1 and 2 (each within the scatter of the next, the first and the last beyond it).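

In this assay, the group on this amide nitrogen can move the number: the change gives a 2.1-fold lower number from compound 2 to compound 3 (0.32 log units; beyond the scatter), a modest step, but the first at this position to lie beyond the scatter. The other comparison gives a 1.2-fold lower number from compound 1 to compound 3 (0.06 log units; within the scatter), so (morpholin-3-yl)methyl and 1-methylpiperidin-4-yl cannot be told apart here, even though the two groups differ in their ring and in how that ring is attached. Nothing measured for these compounds explains the step away from 2-oxopiperidin-4-yl.

Going by these compounds, it remains open whether the step follows the morpholine ring itself or the methyl link that joins it to the amide nitrogen, and a morpholin-3-yl group placed directly on that nitrogen would help separate the two. A (piperidin-3-yl)methyl group or an open 2-aminoethyl chain would test how much of the ring is needed to keep this number.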